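Phenoxycarbonyl in place of benzyl on the aniline nitrogen

This account rests on a few compounds, and the source may have more. Where it says the series, first, only, none or still open, it means among the compounds named here.

Measured so far:
- compound 1 `COc1ccc(S(=O)(=O)N2CCc3cccc(NC(=O)c4ccc(C#N)cc4)c32)cc1`: 89 nM
- compound 2 `COc1ccc(S(=O)(=O)N2CCc3cccc(NS(=O)(=O)c4ccc([N+](=O)[O-])cc4)c32)cc1`: 933 nM
- compound 3 `COc1ccc(S(=O)(=O)N2CCc3cccc(NCc4ccccc4)c32)cc1`: > 10000 nM

In a functional assay on MKN-45 cells (Homo sapiens) for cytotoxicity (a higher number here means a weaker inhibitor, a lower number a stronger inhibitor), compound 1 gives 89 nM, the lowest number of the three. Compound 2 gives 933 nM in this assay. For compound 3 this assay gives only a limit, > 10000 nM, and no number; this is the limit of > 10000 nM in this assay, at which 1 of the 3 values shown sits, so compound 3 stands at the weak end of the series without a value of its own.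

Compound 4 `COc1ccc(S(=O)(=O)N2CCc3cccc(NC(=O)Oc4ccccc4)c32)cc1` differs from compound 3 in one place: phenoxycarbonyl in place of benzyl on a nitrogen on an aromatic ring. Within the data shown here, the one measured step that bears on this change is an at least 110-fold higher number from compound 1 to compound 3 (2.05 log units; beyond the scatter), where removing the carbonyl-bearing substituent from the nitrogen pushed the number up to the limit. The change to compound 4 returns a carbonyl-bearing substituent to that nitrogen, though phenoxycarbonyl is not (4-cyanophenyl)carbonyl, so a large step downward in this assay is expected, though not necessarily all the way back to compound 1. Compound 4 is expected at 400 nM, in the range 60 nM to 4000 nM. This implies an expected step of an at least 25-fold lower number from compound 3 to compound 4 (1.39 log units; beyond the scatter).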

Compound 4, half-maximal inhibitory concentration: > 10000 nM
Compound 4 ended at the assay's limit (the forecaster's own chance of this, stated with the estimate: 15%); middle value at least 25-fold (1.39 log units) from the limit.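

In this assay, keeping a carbonyl on the nitrogen on an aromatic ring does not by itself preserve activity: with phenoxy in place of 4-cyanophenyl on the carbonyl carbon, there is an at least 110-fold higher number from compound 1 to compound 4 (2.05 log units; beyond the scatter). What stands on the carbonyl carbon therefore matters in this series, a point that the change to benzyl in compound 3 could not separate from loss of the carbonyl itself. Compound 3 and compound 4 both stand at a limit of the assay, so the step between them cannot be read, and this limit now recurs in the series: the limit of > 10000 nM in this assay, at which 2 of the 4 values shown sit.

The compounds shown leave open whether the loss follows from the oxygen in the phenoxycarbonyl link or from the absent nitrile. An unsubstituted benzoyl or a phenylacetyl group on that nitrogen would separate these two changes.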